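Benzyl on the ring amine of the pyridone series

A few compounds are considered here, and "the series" means these few. Any claim that something is new, unique, unknown or untested is made for them only; others in the source may bear on it.

Compound 2 `O=c1ccccn1CC1CCNCC1` is the unsubstituted ring amine of the series. In an assay on HEK293 cells for displacement of a labelled ligand from Neuronal acetylcholine receptor; alpha2/beta4 (Rattus norvegicus), tested at 10 uM (on this read-out lower numbers stand for stronger inhibition and higher numbers for weaker inhibition), compound 2 gives 80000 nM, the lowest of the two numbers recorded so far. Compound 1 `O=c1ccccn1CC1CCCN(Cc2ccccc2)C1` carries the benzyl group on the ring nitrogen and the side chain in a different ring position; in this assay compound 1 gives 91000 nM, within the scatter of compound 2, so the two values show no difference to speak of. Compound 3 `O=c1ccccn1CC1CCN(Cc2ccccc2)CC1` is the next member: benzyl in place of hydrogen on an amine nitrogen in a ring. Going by the values given here, no step between measured compounds is available for this change. Since compound 1 with its benzyl group gives 91000 nM and sits level with compound 2, no step beyond the scatter is expected from compound 2 to compound 3 in this assay; the change a 1.1-fold higher number from compound 2 to compound 3 (0.05 log units; within the scatter) is expected to be small. Compound 3 is estimated to give 90000 nM, within a range of 30000 nM to 250000 nM.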

Compound 3, inhibition constant: 440000 nM
Estimate against measurement, compound 3: 4.9-fold (0.69 log units) below, outside the stated range (above it).
By their numbers in this assay, from the lowest: compounds 2 and 1 (each within the scatter of the next); then compound 3.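

In this assay, benzyl in place of hydrogen on an amine nitrogen in a ring gives a step beyond the scatter, a 5.5-fold higher number from compound 2 to compound 3 (0.74 log units; beyond the scatter), a modest move towards weaker inhibition. Compound 1 differs from compound 2 in more than one place and could not isolate this change, whereas the pair of compound 2 and compound 3 does, showing that benzyl on this nitrogen is not neutral on this read-out. The data offer no measured evidence on the origin of this step.

As far as these compounds go, whether the step belongs to the whole benzyl group or to its aromatic ring stays open, and a methyl or cyclohexylmethyl group on the same nitrogen would separate the two. Also open, from the compounds shown here alone, is how a longer chain, such as phenylethyl, would read at this nitrogen.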